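This account rests on a few compounds, and the source may have more. Where it says the series, first, only, none or still open, it means among the compounds named here.

Measured so far in the growth assay:
compound 1, `COc1cc(-c2nn(-c3cccc(NC(=O)Nc4ccc(Cl)c(Cl)c4)c3)cc2-c2ccncc2)ccc1Cl`: 20300 nM
compound 2, `COc1cc(-c2nn(-c3cccc(NC(=O)Nc4ccc(Cl)c(C(F)(F)F)c4)c3)cc2-c2ccncc2)ccc1Cl`: 9140 nM

Both compounds were tested in a functional assay on SF-268 cells (Homo sapiens) for inhibition, read by sulforhodamine B assay, with a stated time of 48 h; a lower number here means a stronger inhibitor of growth, a higher number a weaker inhibitor of growth. Going by the values given here, compound 2 stands at the lowest of the two numbers; the only other compound, compound 1, gives a higher number, and the single measured step, a 2.2-fold lower number from compound 1 to compound 2 (0.35 log units; beyond the scatter), separates them. Among the compounds with values here, that step is the only guide available.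

Compound 3, `COc1cc(-c2nn(-c3cccc(NC(=O)c4ccccc4)c3)cc2-c2ccncc2)ccc1Cl`, has not yet been measured. It differs from compound 2 in one place: phenyl in place of (4-chloro-3-(trifluoromethyl)phenyl)amino on a carbonyl carbon. The measured step concerned only an exchange of one substituent on the very ring that now disappears, together with its attached nitrogen; it showed that the number responds to what sits on that ring, in a modest way. Within the data shown here, no measured step covers the loss of the whole group, so the expectation here is uncertain, and it leans toward a higher number in this assay because the groups that gave the better result in a 2.2-fold lower number from compound 1 to compound 2 (0.35 log units; beyond the scatter) are no longer present. Compound 3 is therefore expected to give about 35000 nM, within a range from 10000 nM to 100000 nM. The expected step is a 3.8-fold higher number from compound 2 to compound 3 (0.58 log units; beyond the scatter).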

Compound 3, concentration for total growth inhibition: > 100000 nM
Compound 3: only a limit was reported (the forecaster's own chance of this, stated with the estimate: 20%); middle value at least 2.8-fold (0.45 log units) away from the limit.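

Compound 3 gives only a limit of the assay, not a number: the limit of > 100000 nM in this assay, at which 1 of the 3 values shown sits.

In this assay, phenyl in place of (4-chloro-3-(trifluoromethyl)phenyl)amino on the carbonyl carbon gives an at least 10-fold higher number from compound 2 to compound 3 (1.03 log units; beyond the scatter), and phenyl in place of (3,4-dichlorophenyl)amino at the same place gives an at least 4.9-fold higher number from compound 1 to compound 3 (0.69 log units; beyond the scatter). Going by these compounds alone, the earlier step, a 2.2-fold lower number from compound 1 to compound 2 (0.35 log units; beyond the scatter), showed only that the number shifts modestly when one substituent on that outer ring is exchanged, whereas these new steps show that losing the whole group costs much more, whichever of the two substituted groups was present.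

This single change removes the nitrogen with its hydrogen-bond donor and both ring substituents at once, so the compounds shown cannot say how much of the loss belongs to each part. From the compounds shown here alone, a plain phenylamino group on the carbonyl carbon would separate the nitrogen from the ring substituents, while a chloro-substituted phenyl there would test the substituent without the nitrogen, and how either would read remains open.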